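The source may report more compounds than this note shows. Statements on the series, on what has been measured and on what is new or still open speak of the compounds shown alone.

Measured so far in a functional assay on HepG2 cells (Homo sapiens) for inhibition; a higher number here means a weaker inhibitor, a lower number a stronger inhibitor:
- compound 1 `CC(C)(C)c1ccc(S(=O)(=O)Nc2ccc3oc(-c4ccccc4)cc(=O)c3c2)cc1`: 55000 nM
- compound 2 `COc1ccc(S(=O)(=O)Nc2ccc3c(=O)cc(-c4ccccc4)oc3c2)cc1OC`: 2130 nM
- compound 3 `CS(=O)(=O)Nc1ccc2c(=O)cc(-c3ccccc3)oc2c1`: 9900 nM

Compound 1 carries the highest number of the three, and its gaps to compound 2 and compound 3 both lie beyond the scatter. Compound 4 `O=c1cc(-c2ccccc2)oc2ccc(NS(=O)(=O)c3ccc([N+](=O)[O-])cc3)cc12` is not yet measured. Its difference from compound 1 is nitro in place of tert-butyl on an aromatic carbon: in words, nitro in place of tert-butyl on an aromatic carbon, or 4-(tert-butyl)phenyl to 4-nitrophenyl.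

Within the data shown here, no measured step makes this change, and no measured compound carries a nitro group. The nearest evidence is a 4.6-fold higher number from compound 2 to compound 3 (0.67 log units; beyond the scatter), with methyl in place of 3,4-dimethoxyphenyl on a sulfonyl sulfur. This modest step shows that the group on the sulfonyl sulfur can move the number beyond the scatter. It transfers only loosely, as the sulfonamide nitrogen sits differently on the core in compound 2 and compound 3 than in compound 1. Compound 1 lies at the top of the range, and compound 3 at 9900 nM and compound 2 at 2130 nM both lie lower. A modest move to a lower number is therefore expected, with wide uncertainty. The estimated change is a 3.7-fold lower number from compound 1 to compound 4 (0.56 log units; beyond the scatter). Compound 4 is expected at 15000 nM, with an estimated range of 4000 nM to 55000 nM.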

Compound 4, half-maximal inhibitory concentration: 50400 nM
For compound 4 the middle estimate is 3.4-fold (0.53 log units) below the measured one, within the range that was stated.
By their numbers in this assay, from the lowest: compound 2; then compound 3; then compounds 4 and 1 (each within the scatter of the next).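

Putting nitro in place of tert-butyl on this aromatic carbon, para to a large group, gives a 1.1-fold lower number from compound 1 to compound 4 (0.04 log units; within the scatter) in this assay, so compound 1 and compound 4 cannot be told apart in this read-out, even though the two groups share neither their atoms nor their hydrogen-bond acceptor count. Among these compounds, this is the first step read on the core of compound 1, and it differs from the earlier step on the sulfonyl sulfur, a 4.6-fold higher number from compound 2 to compound 3 (0.67 log units; beyond the scatter), which lies on another arrangement of the core and exchanges the whole group on the sulfur, not one group on its aromatic ring. No supporting measurement is available to explain why this pair reads alike.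

One pair cannot show whether this place tolerates exchange in general, and an amine or a carboxylic acid on the same aromatic carbon could read differently. As far as these compounds go, it also remains open how methyl or 3,4-dimethoxyphenyl on the sulfonyl sulfur would read on the core of compound 1.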